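Swapping chloro for bromo on a diaryl thioether nitrile

This account rests on a few compounds, and the source may have more. Where it says the series, first, only, none or still open, it means among the compounds named here.

Measured so far:
compound 1, `N#Cc1ccc(Sc2ccc(Br)cc2)cc1C#N`: 79 nM
compound 2, `N#Cc1ccc(Sc2ccc(Cl)cc2)cc1`: 4280 nM

Of the compounds shown here, two have been tested in an assay on microsomes for inhibition of Amine oxidase [flavin-containing] B (Homo sapiens), read by fluorescence and spectrophotometry, with a stated time of 20 min; on this read-out lower numbers stand for stronger inhibition and higher numbers for weaker inhibition. Compound 1 gives 79 nM, and compound 2 gives 4280 nM. Compound 2 thus stands with the higher of the two numbers, and its gap to compound 1 lies well beyond the usual scatter. Among the measured compounds shown here, the two structures differ in more than one place, so no single step between them can be read off.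

Compound 3 is `N#Cc1ccc(Sc2ccc(Br)cc2)cc1`. It is built from compound 2 by one change: bromo in place of chloro on an aromatic carbon. For the measured compounds named here, no measured pair shows this exchange on its own, so its effect is unknown from the data at hand. A change this small is expected to move the number little, if at all, and any shift is expected to stay close to the scatter.

Compound 3 is therefore estimated at 3000 nM, with a plausible range from 900 nM to 9000 nM. That estimate means a step of a 1.4-fold lower number from compound 2 to compound 3 (0.15 log units; within the scatter), expected to be small.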

Compound 3, half-maximal inhibitory concentration: 637 nM
For compound 3 the middle estimate is 4.7-fold (0.67 log units) above the measured one, and the stated range ends above it.
By their numbers in this assay, from the lowest: compound 1; then compound 3; then compound 2.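

In this assay bromo in place of chloro on this aromatic carbon gives a 6.7-fold lower number from compound 2 to compound 3 (0.83 log units; beyond the scatter) and so shows that exchanging this single atom matters on the shared core. Compound 3 also connects the two earlier compounds, which differ in more than one place: hydrogen in place of cyano gives an 8.1-fold higher number from compound 1 to compound 3 (0.91 log units; beyond the scatter) and so shows that losing the second nitrile of compound 1 also goes with a weaker result. No measurement shown here explains why either change has this effect.

As far as these compounds go, it remains open whether bromo in place of chloro would give a step of similar size on a core that keeps both nitriles. From the compounds shown here alone, it also remains open how other groups on this aromatic carbon, such as iodo, methoxy or an amine, would compare with bromo.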